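Halogen swap on the sulfonyl ring of two anilide cores

The source may report more compounds than this note shows. Statements on the series, on what has been measured and on what is new or still open speak of the compounds shown alone.

Four sulfonamides are under review. Compound 1 `O=[N+]([O-])c1cccc(NS(=O)(=O)c2ccc(Cl)cc2)c1` and compound 2 `O=[N+]([O-])c1cccc(NS(=O)(=O)c2ccc(Br)cc2)c1` share one core; compound 3 `O=S(=O)(Nc1ccc(Cl)cc1)c1ccc(Cl)cc1` and compound 4 `O=S(=O)(Nc1ccc(Cl)cc1)c1ccc(Br)cc1` share another. The difference between the two cores is not broken down here. In a physicochemical assay for acid dissociation, compound 1 gives 7.51, and compound 2 gives 7.42; the change between them, (bromo in place of chloro on an aromatic carbon), produced a number 0.09 log units lower from compound 1 to compound 2 (within the scatter). In this assay compound 3 gives 8.3, the highest of the three numbers. Compound 4 carries the same change on its core, (bromo in place of chloro on an aromatic carbon), at a place described in the same words. The step is expected to be a number 0.10 log units lower from compound 3 to compound 4 (within the scatter) because the same change gave a number 0.09 log units lower from compound 1 to compound 2 (within the scatter). Compound 4 is therefore expected to give 8.2, estimated between 7.9 and 8.5.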

Compound 4, acid dissociation constant: 8.24
The estimate for compound 4 lay 0.04 log units below the measured number; measured number inside the range.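

In this assay bromo in place of chloro on an aromatic carbon gives a number 0.06 log units lower from compound 3 to compound 4 (within the scatter) on one core and a number 0.09 log units lower from compound 1 to compound 2 (within the scatter) on the other. Among these compounds, on these two cores the change therefore carries over with no step that can be told from the scatter, but two pairs at one kind of place do not show that it would do so on any further core. Nothing available bears on why the two steps agree.

The compounds shown leave open what a group other than chloro or bromo, such as an amine or a carboxylic acid, would do at the same place. They also leave open whether such a group would give the same step on both cores.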